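The source may hold more compounds than are shown below. What is called first, only, known or untested is meant among the compounds shown, and "the series" means these compounds.

Series of anilides on the shared core. In a functional assay on KG-1 cells (Homo sapiens) for cytotoxicity, read by luminescence and CellTiter-Glo, with a stated time of 3 days (a lower number here means a stronger inhibitor, a higher number a weaker inhibitor), compound 1 `N#Cc1ccc(NC(=O)c2cc(Cc3ccccc3)ccc2O)cc1` gives 1930 nM, compound 2 `N#Cc1ccc(NC(=O)c2cc(Br)ccc2O)cc1` gives 1290 nM, and compound 3 `N#Cc1ccc(NC(=O)c2cc(-c3cccnc3)ccc2O)cc1` gives 8330 nM. Compound 3 stands highest of the three numbers: a 4.3-fold higher number from compound 1 to compound 3 (0.64 log units; beyond the scatter), and a 6.5-fold higher number from compound 2 to compound 3 (0.81 log units; beyond the scatter), while a 1.5-fold lower number from compound 1 to compound 2 (0.17 log units; within the scatter).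

Compound 4 `Cc1ccc(O)c(C(=O)Nc2ccc(C#N)cc2)c1` has not yet been measured in this assay. It differs from compound 3 in one place: methyl in place of pyridin-3-yl on an aromatic carbon. The two steps that bear on this are those that brought pyridin-3-yl in: from compound 1 it raised the number and from compound 2 it raised it further. Removing pyridin-3-yl again, this time for methyl, is therefore expected to lower the number, with compound 2 giving a reference for a small group on that aromatic carbon. The step is estimated as a 4.6-fold lower number from compound 3 to compound 4 (0.67 log units; beyond the scatter). For compound 4 the expected value is 1800 nM, with a range of 700 nM to 4500 nM.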

Compound 4, half-maximal inhibitory concentration: 3370 nM
The estimate for compound 4 lay 1.9-fold (0.27 log units) below the measured number; low and high end bracket the measured number.
By their numbers in this assay, from the lowest: compounds 2, 1 and 4 (each within the scatter of the next, the first and the last beyond it); then compound 3.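

In this assay, methyl only partly offsets the cost of pyridin-3-yl at this position, para to the hydroxy group: a 2.5-fold lower number from compound 3 to compound 4 (0.39 log units; beyond the scatter), yet a 2.6-fold higher number from compound 2 to compound 4 (0.42 log units; beyond the scatter), so this carbon distinguishes methyl from bromo, and compound 3 remains beyond the scatter of both compound 2 and compound 4. Shortening benzyl to methyl is a different case: a 1.7-fold higher number from compound 1 to compound 4 (0.24 log units; within the scatter), so the data show no effect of the phenyl of the benzyl group. Nothing available explains the differences among bromo, methyl, benzyl and pyridin-3-yl.

Going by these compounds, whether the higher number of compound 3 belongs to the ring nitrogen remains open, and a directly attached phenyl would test this. Also open, on these data alone, is how a methoxy group, an aminomethyl group or a carboxylic acid would read at this carbon.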